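Shortening the Amide Side Chain: What to Expect

The source may report more compounds than this note shows. Statements on the series, on what has been measured and on what is new or still open speak of the compounds shown alone.

Of the compounds shown here, three sharing one core have been tested in a functional assay on the whole organism (Tail, strain ICR) with Mus musculus as the target, in the tail flick test, with a stated time of 90 min, at a dose of 25 umol/kg by the oral route; a lower number here means a weaker effect, a higher number a stronger effect of the compound at the dose given. Compound 1 `O=C(CN(c1nc(Cl)nc2[nH]cnc12)C1CC1)NCC(=O)OCc1ccccc1` gives 27.2%. Compound 2 `NC(=O)CC[C@H](NC(=O)CN(c1nc(Cl)nc2[nH]cnc12)C1CC1)C(=O)O` gives 41.1%, and compound 3 `NC(=O)CC[C@H](NC(=O)CN(c1nc(Cl)nc2[nH]cnc12)C1CC1)C(=O)OCc1ccccc1` gives 42.8%. Compound 2 thus stands second highest of the three: its value and that of compound 3 lie within the scatter of each other, while compound 1 sits lower, beyond the scatter.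

Two steps have been measured. a number 15.6 percentage points higher from compound 1 to compound 3 (beyond the scatter) shows that building the chain out from a bare hydrogen brought a modest gain. a number 1.7 percentage points higher from compound 2 to compound 3 (within the scatter) shows that the benzyl on the ester oxygen made no difference beyond the scatter.

Compound 4 `NC(=O)C[C@H](NC(=O)CN(c1nc(Cl)nc2[nH]cnc12)C1CC1)C(=O)O` differs from compound 2 by carbamoyl in place of carbamoylmethyl on a saturated chain carbon, two bonds along the chain from an amide-type nitrogen and a carbonyl carbon. Among the compounds with values here, no measured step shortens this chain from carbamoylmethyl to carbamoyl; the closest guide is the first step, in which the whole chain was worth only a modest amount. Trimming part of it is therefore expected to cost little or nothing beyond the scatter, and the expected step is a number 4.1 percentage points lower from compound 2 to compound 4 (within the scatter). Compound 4 is estimated at 37%, with a range from 25% to 49%.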

Compound 4, a percentage reported as activity, at one dose (the size of the read-out at that dose, not a potency): 20.1%
Beside the measured number, compound 4's estimate is 16.9 percentage points above it; measured number below the stated range.
By their numbers in this assay, from the lowest: compounds 4 and 1 (each within the scatter of the next); then compounds 2 and 3 (each within the scatter of the next).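

In this assay, cutting the 2-carbamoylethyl chain to carbamoylmethyl gives a number 21 percentage points lower from compound 2 to compound 4 (beyond the scatter), even though the carbamoyl end of the chain stays in place. The earlier step compared the whole chain with a bare hydrogen, whereas this one shows that the length of the chain at this position matters, not only its presence. Nothing available here explains why the shorter chain gives a lower number.

Still open, on these data alone, is what a longer chain, such as 3-carbamoylpropyl, would do at this position, since only these two chain lengths can be compared directly. As far as these compounds go, it is also open whether a carboxylic acid or an amine at the end of the chain, in place of the carbamoyl, would keep the effect seen with the 2-carbamoylethyl chain.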